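This account rests on a few compounds, and the source may have more. Where it says the series, first, only, none or still open, it means among the compounds named here.

In a functional assay on A-431 cells (Homo sapiens) for antiproliferative activity, read by MTT assay, with a stated time of 72 h (a higher number here means a weaker inhibitor, a lower number a stronger inhibitor), the measured compounds are:
Compound 1 `C=CC(=O)Nc1cc2c(Nc3ccc(F)c(Cl)c3)ncnc2cc1OCc1cn(CCC(=O)NO)nn1` gives 22100 nM
Compound 2 `C=CC(=O)Nc1cc2c(Nc3cccc(Cl)c3F)ncnc2cc1OCc1cn(CCCCC(=O)NO)nn1` gives 15600 nM
Compound 3 `C=CC(=O)Nc1cc2c(Nc3ccc(F)c(Cl)c3)ncnc2cc1OCc1cn(CCCCC(=O)NO)nn1` gives 15000 nM

Compound 2 (15600 nM) lies within the scatter of both other compounds, so the three values set no order. Compound 4 `C=CC(=O)Nc1cc2c(Nc3cccc(Cl)c3F)ncnc2cc1OCc1cn(CCC(=O)NO)nn1` differs from compound 2 by hydroxycarbamoyl in place of 2-(hydroxycarbamoyl)ethyl on a saturated chain carbon, two bonds along the chain from an aromatic nitrogen, with hydroxycarbamoyl in place of 2-(hydroxycarbamoyl)ethyl on a saturated chain carbon, two bonds along the chain from an aromatic nitrogen. The same chain difference, read in the opposite direction, is a 1.5-fold lower number from compound 1 to compound 3 (0.17 log units; within the scatter), and it stays within the scatter. The aryl exchange, a 1.0-fold lower number from compound 2 to compound 3 (0.02 log units; within the scatter), also stays within the scatter. In this assay no step beyond the scatter is therefore expected, only a possible small rise. The expected step is a 1.4-fold higher number from compound 2 to compound 4 (0.15 log units; within the scatter), and this is an estimate. Compound 4 is estimated at 22000 nM (expected range 12000 nM to 40000 nM).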

Compound 4, half-maximal inhibitory concentration: 15000 nM
Estimate against measurement, compound 4: 1.5-fold (0.17 log units) above; the range from low to high includes it.
By their numbers in this assay, from the lowest: compounds 3, 4, 2 and 1 (each within the scatter of the next).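

In this assay the shorter chain, hydroxycarbamoyl in place of 2-(hydroxycarbamoyl)ethyl at this place, can now be read with the 3-chloro-2-fluorophenyl group as well (a 1.0-fold lower number from compound 2 to compound 4 (0.02 log units; within the scatter)), so the chain step no longer rests on one pair: the same change on two cores in this assay, a 1.5-fold lower number (0.17 log units; within the scatter) from compound 1 to compound 3 and a 1.0-fold higher number (0.02 log units; within the scatter) from compound 4 to compound 2, 1.5-fold (0.19 log units) apart, within the scatter of two such steps

The aryl exchange likewise now has a second pair, on the shorter chain (a 1.5-fold lower number from compound 1 to compound 4 (0.17 log units; within the scatter)): the same change on two cores in this assay, a 1.0-fold lower number (0.02 log units; within the scatter) from compound 2 to compound 3 and a 1.5-fold higher number (0.17 log units; within the scatter) from compound 4 to compound 1, 1.5-fold (0.19 log units) apart, within the scatter of two such steps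

Going by these compounds, whether a chain longer than 4-(hydroxycarbamoyl)butyl, or a carboxylic acid in place of the hydroxycarbamoyl end, would step beyond the scatter stays open.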